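A few compounds are considered here, and "the series" means these few. Any claim that something is new, unique, unknown or untested is made for them only; others in the source may bear on it.

Measured compounds in a functional assay on Jurkat cells (Homo sapiens) for inhibition, read by MTT assay, with a stated time of 72 h; a higher number here means a weaker inhibitor of growth, a lower number a stronger inhibitor of growth:
compound 1, `CCCCc1nc(C(=O)OC)nn1-c1ccc(F)cc1`: compound 1 gives > 100000 nM, a limit of the assay and not a number.
compound 2, `COC(=O)c1nc(-c2ccsc2)n(-c2ccc(F)cc2)n1`: compound 2 gives 54000 nM.

Going by the values given here, compound 2 thus stands as the only compound with a number in this assay. The other value shown, that of compound 1, is the limit of > 100000 nM in this assay, at which 1 of the 2 values shown sits. Among the compounds with values here, the single measured step, an at least 1.8-fold lower number from compound 1 to compound 2 (0.26 log units; that floor lies within the scatter), is thiophen-3-yl in place of butyl on an aromatic carbon, and its floor lies within the scatter. Compound 3, `COC(=O)c1nc(-c2ccsc2)n(-c2ccc(C(F)(F)F)cc2)n1`, differs from compound 2 by trifluoromethyl in place of fluoro on an aromatic carbon. No measured step in the series touches the six-membered aromatic ring of carbon only, so the one measured step does not bear on this change, and nothing shown supports a direction. For compound 3 the expected step is a 1.1-fold lower number from compound 2 to compound 3 (0.03 log units; within the scatter), none beyond the scatter. Compound 3 is therefore estimated at 50000 nM in this assay, with a range from 15000 nM to 150000 nM.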

Compound 3, concentration for 50% growth inhibition: > 100000 nM
Compound 3 ended at the assay's limit (the forecaster's own chance of this, stated with the estimate: 35%); middle value at least 2.0-fold (0.30 log units) from the limit.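

Going by these compounds alone, this is the first measured change on the six-membered aromatic ring of carbon only, para to a large group, and in this assay trifluoromethyl in place of fluoro gives an at least 1.8-fold higher number from compound 2 to compound 3 (0.26 log units; that floor lies within the scatter), so no gain in growth inhibition appears, while a loss is not established. The value of compound 3 is a limit of the assay and not a number. Only compound 2 therefore still carries a number, and the series sits mostly at the limit: the limit of > 100000 nM in this assay, at which 2 of the 3 values shown sit.

As far as these compounds go, whether any group at this place can improve on the fluoro of compound 2 stays open, and an amine or a methoxy group there would bear on that question. Also open, from the compounds shown here alone, is how much the methyl ester contributes, which a carboxylic acid or an amide at that place would test.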